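Removing the methyl from compound 2

The compounds below may be only part of what the source reports. "The series", "measured", "known", "first", "only" and "open" are said of these compounds alone.

Compound 1 `O=S(=O)(Nc1cscn1)c1cc(Cl)c(NCc2cc(F)ccc2F)cc1F` and compound 2 `C[C@H](Nc1cc(F)c(S(=O)(=O)Nc2cscn2)cc1Cl)c1cc(CN2CCC2)ccc1F` share a common core and were both tested in an assay on HEK293 cells for inhibition of SCN8A/SCN1B (Homo sapiens), read by patch clamp, with a stated time of 20 min; a lower number here means a stronger inhibitor, a higher number a weaker inhibitor. In that assay compound 1 gives 450 nM, while compound 2 gives 120 nM, the lowest of the two numbers and a gap to compound 1 that lies beyond the usual scatter. Compound 3 `O=S(=O)(Nc1cscn1)c1cc(Cl)c(NCc2cc(CN3CCC3)ccc2F)cc1F` is derived from compound 2 by a single change: hydrogen in place of methyl on a saturated chain carbon bound to an aromatic carbon and a nitrogen on an aromatic ring. Going by the values given here, no measured pair shows this change alone. The step of a 2.1-fold higher number from compound 2 to compound 3 (0.32 log units; beyond the scatter) is expected to be a small loss, close to the scatter. Compound 3 is therefore expected near 250 nM, with a range from 100 nM to 650 nM.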

Compound 3, half-maximal inhibitory concentration in the SCN8A/SCN1B assay: 460 nM
Beside the measured number, compound 3's estimate is 1.8-fold (0.26 log units) below it; measured number inside the range.
By their numbers in the SCN8A/SCN1B assay, from the lowest: compound 2; then compounds 1 and 3 (each within the scatter of the next).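

In the SCN8A/SCN1B assay the methyl on this saturated chain carbon proves to matter: hydrogen in its place gives (a 3.8-fold higher number from compound 2 to compound 3 (0.58 log units; beyond the scatter)), while in a physicochemical assay for lipophilicity, read by LC-MS, in phosphate buffer, measured as octanol-water partition, with a stated time of 1 h, at pH 7.4 (on this read-out higher numbers stand for higher lipophilicity and lower numbers for lower lipophilicity), compound 2 gives 1.5 and compound 3 gives 1.4 (a number 0.10 log units lower from compound 2 to compound 3 (within the scatter)). Without that methyl, (azetidin-1-yl)methyl in place of fluoro leaves compound 1 and compound 3 indistinguishable in the SCN8A/SCN1B assay (a 1.0-fold higher number from compound 1 to compound 3 (0.01 log units; within the scatter)). Nothing shown accounts for the methyl's contribution. Open, as far as these compounds go, is whether an ethyl or cyclopropyl on that carbon would match the methyl, and whether the methyl counts equally with fluoro in place of (azetidin-1-yl)methyl.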